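Ring-nitrogen substituent: oxygen chains against branched alkyl

This account rests on a few compounds, and the source may have more. Where it says the series, first, only, none or still open, it means among the compounds named here.

Measured so far in a functional assay on ileum for inhibition of histamine H1 receptor (Cavia porcellus); a lower number here means a stronger inhibitor, a higher number a weaker inhibitor:
compound 1 `CCOCCn1c(N2CCN(C)CC2)nc2ccccc21` gives 10 nM
compound 2 `CCCOCCn1c(N2CCN(C)CC2)nc2ccccc21` gives 20 nM
compound 3 `CCCC(C)n1c(N2CCN(C)CC2)nc2ccccc21` gives 1400 nM

Compound 3 stands at the highest number of the three; the steps to it, a 140-fold higher number from compound 1 to compound 3 (2.15 log units; beyond the scatter) and a 70-fold higher number from compound 2 to compound 3 (1.85 log units; beyond the scatter), are both large and beyond the scatter, while a 2.0-fold higher number from compound 1 to compound 2 (0.30 log units; within the scatter) stays within it. Compound 4 `CCCSCn1c(N2CCN(C)CC2)nc2ccccc21` differs from compound 3 only at the ring nitrogen: (propylsulfanyl)methyl in place of 1-methylbutyl on an aromatic nitrogen. Both large steps bear on this change, since each removed a chain carrying an oxygen from that nitrogen and each raised the number strongly. Among the measured compounds shown here, compound 4 returns a chain with a heteroatom acceptor to the same nitrogen, so the estimate is a step back downward, expected as a 14-fold lower number from compound 3 to compound 4 (1.15 log units; beyond the scatter), though sulfur and the (propylsulfanyl)methyl arrangement have no measured precedent here, so the range is kept wide. Compound 4 is expected at 100 nM, between 20 nM and 600 nM.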

Compound 4, half-maximal inhibitory concentration: 68 nM
Estimate against measurement, compound 4: 1.5-fold (0.17 log units) above; the measured number falls inside the stated range.
By their numbers in this assay, from the lowest: compounds 1 and 2 (each within the scatter of the next); then compound 4; then compound 3.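

In this assay, a sulfur-bearing chain on the aromatic nitrogen gives a 21-fold lower number from compound 3 to compound 4 (1.31 log units; beyond the scatter), so an oxygen chain is not the only kind that lowers the number relative to 1-methylbutyl. The return is only partial, with a 3.4-fold higher number from compound 2 to compound 4 (0.53 log units; beyond the scatter) and a 6.8-fold higher number from compound 1 to compound 4 (0.83 log units; beyond the scatter), and in these steps the heteroatom and the chain arrangement change together. Nothing available accounts for these steps.

Still open, as far as these compounds go, is whether sulfur itself or its place along the chain sets the gap to compound 1 and compound 2. A 2-(propylsulfanyl)ethyl or propoxymethyl group on this nitrogen would separate the two.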